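Bromo to Methyl on the Ring: Expected Half-Life

This account rests on a few compounds, and the source may have more. Where it says the series, first, only, none or still open, it means among the compounds named here.

Compound 2 `O=C(NCc1ccccc1Br)N1C(=O)c2ccccc2S1(=O)=O` stands lowest of the two numbers in a physicochemical assay for pharmacokinetics (on this read-out lower numbers stand for a shorter-lived compound and higher numbers for a longer-lived compound), giving 0.253 h. Its nearest neighbour, compound 1 `O=C(NCc1cccs1)N1C(=O)c2ccccc2S1(=O)=O`, gives 0.365 h in this assay. That gap, a 1.4-fold lower number from compound 1 to compound 2 (0.16 log units; within the scatter), lies within the scatter. Compound 3 `Cc1ccccc1CNC(=O)N1C(=O)c2ccccc2S1(=O)=O` differs from compound 2 by methyl in place of bromo on an aromatic carbon. No measured step exchanges one group for another on this six-membered ring; the only step shown, a 1.4-fold lower number from compound 1 to compound 2 (0.16 log units; within the scatter), changed the whole aromatic group and still stayed within the scatter. The step is therefore expected to be a 1.0-fold lower number from compound 2 to compound 3 (0.01 log units; within the scatter). Compound 3 is estimated at 0.25 h, between 0.13 h and 0.5 h.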

Compound 3, half-life: 0.792 h
Beside the measured number, compound 3's estimate is 3.2-fold (0.50 log units) below it, and the stated range ends below it.
By their numbers in this assay, from the lowest: compounds 2 and 1 (each within the scatter of the next); then compound 3.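

In this assay, methyl in place of bromo on an aromatic carbon gives a 3.1-fold higher number from compound 2 to compound 3 (0.50 log units; beyond the scatter) and so shows that exchanging a single heavy atom at this ortho place can move the number beyond the scatter. The earlier pair, with its whole aromatic group changed, did not show this. The 2-methylphenyl group also stands apart from thiophen-2-yl, with a 2.2-fold higher number from compound 1 to compound 3 (0.34 log units; beyond the scatter) and compound 3 as the longest-lived of the three.

From the compounds shown here alone, whether chloro, ethyl or methoxy at this place would track methyl or bromo remains open. Nothing at hand explains the shift.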